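Removing the benzothiophene arm: a step toward cyclopropylmethyl

The source may report more compounds than this note shows. Statements on the series, on what has been measured and on what is new or still open speak of the compounds shown alone.

Measured compounds:
Compound 1, `Cc1cc(Nc2ccn(Cc3cccc4ccccc34)n2)n2nc(SCc3ccc(Br)cc3)nc2n1`, 3240 nM
Compound 2, `Cc1cc(Nc2cc(-c3ccccc3)[nH]n2)n2nc(SCc3csc4ccccc34)nc2n1`, 2280 nM
Compound 3, `Cc1cc(Nc2ccn(Cc3ccc(C(F)(F)F)cc3)n2)n2nc(SCc3ccc(Br)cc3)nc2n1`, 2590 nM

Among the measured compounds shown here, in a functional assay on MGC-803 cells (Homo sapiens) for inhibition, read by MTT assay, with a stated time of 72 h (on this read-out lower numbers stand for stronger inhibition and higher numbers for weaker inhibition), compound 1 gives 3240 nM and compound 3 gives 2590 nM; the only single-change step among the measured compounds, a 1.3-fold lower number from compound 1 to compound 3 (0.10 log units; within the scatter), sits within the scatter. Compound 2 gives 2280 nM in this assay, a number that lies within the scatter of both compound 1 and compound 3, so the three measured compounds cannot be separated from one another.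

Compound 4, `Cc1cc(Nc2cc(-c3ccccc3)[nH]n2)n2nc(SCC3CC3)nc2n1`, has not been measured in this assay. It differs from compound 2 by cyclopropyl in place of 1-benzothiophen-3-yl on a saturated chain carbon bound to a sulfur. For the measured compounds named here, no measured step touches the group on the sulfur side; the one known step concerns the other end of the shared core and is within the scatter, so it gives no direct guide. Because compound 2 gives 2280 nM and the change removes a large aromatic group, a step in this assay toward weaker inhibition is expected, of about a 2.9-fold higher number from compound 2 to compound 4 (0.45 log units; beyond the scatter). Compound 4 is therefore estimated at 6500 nM, with a range from 2000 nM to 22000 nM.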

Compound 4, half-maximal inhibitory concentration: 16100 nM
Compound 4: the middle estimate sits 2.5-fold (0.39 log units) below what was measured; measured number inside the range.
By their numbers in this assay, from the lowest: compounds 2, 3 and 1 (each within the scatter of the next); then compound 4.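

In this assay, the group on a saturated chain carbon bound to a sulfur is the first place among these compounds where a single change moves the number beyond the scatter: cyclopropyl in place of 1-benzothiophen-3-yl gives a 7.1-fold higher number from compound 2 to compound 4 (0.85 log units; beyond the scatter). Among the compounds shown here, the only earlier step, a 1.3-fold lower number from compound 1 to compound 3 (0.10 log units; within the scatter), lay within the scatter and concerned a different place, so it gave no sign that the assay could respond to a change of this kind. Nothing measured here explains the size of this step.

This single pair leaves open whether the number follows the aromatic rings that leave or simply the heavy atoms that are lost. From the compounds shown here alone, a phenyl ring or a longer alkyl chain in the same place could separate these two readings, and an amine there remains equally open.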